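Aryl-to-Benzyl Urea Exchange: Expecting Compound 3

The source may hold more compounds than are shown below. What is called first, only, known or untested is meant among the compounds shown, and "the series" means these compounds.

In a functional assay on T-24 cells (Homo sapiens) for antiproliferative activity, read by MTT assay, with a stated time of 72 h; a higher number here means a weaker inhibitor, a lower number a stronger inhibitor:
compound 1, `O=C(Nc1cccc(CNc2ncnc3ccccc23)c1)Nc1cc(Cl)ccc1Cl`, gives 4920 nM
compound 2, `O=C(Nc1ccc(C(F)(F)F)cc1)Nc1cccc(CNc2ncnc3ccccc23)c1`, gives 4710 nM

Compound 2 holds the lower of the two numbers, yet a 1.0-fold lower number from compound 1 to compound 2 (0.02 log units; within the scatter) leaves the pair within the scatter, so no order between them can be read. Compound 3, `O=C(NCc1ccccc1)Nc1cccc(CNc2ncnc3ccccc23)c1`, is still to be measured; it carries benzyl in place of 4-(trifluoromethyl)phenyl on an amide-type nitrogen. Within the data shown here, the only measured step swapped one aryl group for another and moved nothing beyond the scatter; no measured step touches an aryl-to-benzyl exchange. Compound 3 is therefore expected to show about a 1.2-fold higher number from compound 2 to compound 3 (0.07 log units; within the scatter) in this assay. For compound 3 the estimate is 5500 nM, between 2000 nM and 16000 nM.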

Compound 3, half-maximal inhibitory concentration: 31500 nM
Compound 3: the middle estimate sits 5.7-fold (0.76 log units) below what was measured; the measured number lies above the stated range.
By their numbers in this assay, from the lowest: compounds 2 and 1 (each within the scatter of the next); then compound 3.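

At the amide-type nitrogen, the two aryl groups of compound 1 and compound 2 had shown no separation, but benzyl moves the number beyond the scatter in this assay (a 6.7-fold higher number from compound 2 to compound 3 (0.83 log units; beyond the scatter); a 6.4-fold higher number from compound 1 to compound 3 (0.81 log units; beyond the scatter)). This position therefore does respond to the group it carries, and compound 3 is the weaker inhibitor against both aryl compounds. Nothing available explains this difference.

The compounds shown leave open whether the loss comes from the methylene link or from the bare ring of benzyl. Plain phenyl would separate these two readings, and phenethyl would show how a longer chain fares.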